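Swapping an arylcarbonyl for an arylcarbamoyl group

The source may hold more compounds than are shown below. What is called first, only, known or untested is meant among the compounds shown, and "the series" means these compounds.

Of the compounds shown here, three that share a common core have been tested in a functional assay on M14 cells (Homo sapiens) for inhibition, read by sulforhodamine B assay, with a stated time of 48 h; a lower number here means a stronger inhibitor of growth, a higher number a weaker inhibitor of growth. Compound 1 `O=C(Nc1cccc(-n2cc(-c3ccncc3)c(-c3ccc(Cl)c(O)c3)n2)c1)Nc1cccc(C(F)(F)F)c1` gives 1400 nM, and compound 2 `COc1cc(-c2nn(-c3cccc(NC(=O)Nc4cc(C(F)(F)F)cc(C(F)(F)F)c4)c3)cc2-c2ccncc2)ccc1Cl` gives 808 nM. Compound 3 `COc1cc(-c2nn(-c3cccc(NC(=O)c4cccc(C(F)(F)F)c4)c3)cc2-c2ccncc2)ccc1Cl` gives 1630 nM, the highest of the three numbers, yet both other values lie within the usual scatter of it, so no ordering among the three can be read from these figures.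

The next compound keeps the core of compound 3 and alters only the group on the carbonyl carbon: compound 4 `COc1cc(-c2nn(-c3cccc(NC(=O)Nc4ccc(Cl)c(Cl)c4)c3)cc2-c2ccncc2)ccc1Cl` carries (3,4-dichlorophenyl)amino in place of 3-(trifluoromethyl)phenyl on a carbonyl carbon. Read one bond further out, a (3-(trifluoromethyl)phenyl)carbonyl becomes a (3,4-dichlorophenyl)carbamoyl, which brings compound 4 closer in build to compound 1 and compound 2, both of which carry a carbamoyl-type link to their outer aromatic ring.

Among the compounds with values here, no pair of measured compounds shows this exact change, so its size is not known here. Given that compound 2 gives 808 nM with such a link, a modest move toward a lower number is expected for compound 4, with a step of a 1.8-fold lower number from compound 3 to compound 4 (0.26 log units; within the scatter). Compound 4 is thus estimated at 900 nM in this assay, within a range from 350 nM to 2500 nM.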

Compound 4, concentration for 50% growth inhibition: 911 nM
For compound 4 the middle estimate is 1.0-fold (0.01 log units) below the measured one, within the range that was stated.
By their numbers in this assay, from the lowest: compounds 2, 4, 1 and 3 (each within the scatter of the next).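

In this assay, within the data shown here, this is the first direct reading at this place, the carbonyl carbon whose other neighbour is an amide-type nitrogen: putting (3,4-dichlorophenyl)amino in place of 3-(trifluoromethyl)phenyl gives a 1.8-fold lower number from compound 3 to compound 4 (0.25 log units; within the scatter), so the two compounds cannot be told apart. The swap is therefore accepted on this core without any measurable loss, even though it alters two things at once: the link gains a nitrogen carrying a hydrogen-bond donor, and the substituents on the outer ring are exchanged. Among these compounds, no measurement here explains this result, and the single step cannot assign any share of it to the new link or to the chlorine atoms.

The compounds shown leave open what the link alone would do, a question that (3-(trifluoromethyl)phenyl)amino on this same core, with its outer ring held fixed, could answer. They also leave open whether this place needs an aromatic ring at all, which a morpholine or a simple alkyl chain on the same carbonyl carbon would test.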